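A methyl added to the chain of compound 1

The source may report more compounds than this note shows. Statements on the series, on what has been measured and on what is new or still open speak of the compounds shown alone.

Measured in a functional assay on the whole organism for inhibition, with Rattus norvegicus as the target; on this read-out higher numbers stand for an effect only at larger amounts of compound and lower numbers for an effect already at smaller amounts:
Compound 1 `CC(C)c1ccc(OC(C)(Cc2ccc(Cl)cc2)C(=O)NS(=O)(=O)C(F)(F)F)cc1`: 5 mg/kg
Compound 2 `CC(C)c1ccc(OC(C)(Cc2ccc(Cl)cc2)c2nnn[nH]2)cc1`: 10 mg/kg
Compound 3 `CC(C)c1ccc(OC(C)(Cc2ccc(Cl)cc2)C(=O)CO)cc1`: > 10 mg/kg, a limit

Going by the values given here, only two compounds have numbers, and these do not separate: a 2.0-fold higher number from compound 1 to compound 2 (0.30 log units; within the scatter). Compound 1 thus stands clearly apart from neither of the others. Compound 4 `CC(C)c1ccc(OC(C)(C(=O)NS(=O)(=O)C(F)(F)F)C(C)c2ccc(Cl)cc2)cc1` has methyl in place of hydrogen on a saturated chain carbon bound to an aromatic carbon and a saturated chain carbon, so 4-chlorobenzyl becomes 1-(4-chlorophenyl)ethyl. Among the compounds with values here, no measured step changes that carbon. The closest guides, a 2.0-fold higher number from compound 1 to compound 2 (0.30 log units; within the scatter) and an at least 2.0-fold higher number from compound 1 to compound 3 (0.30 log units; that floor lies within the scatter), alter the ((trifluoromethyl)sulfonyl)carbamoyl group instead and give no size for this change. The expected step is a 1.2-fold higher number from compound 1 to compound 4 (0.08 log units; within the scatter), and none beyond the scatter is expected. For compound 4 the estimate is 6 mg/kg, with an expected range from 2 mg/kg to 20 mg/kg.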

Compound 4, dose for half-maximal effect: > 10 mg/kg
Compound 4 gave a limit, no number; the forecaster's own chance of this, stated with the estimate: 25%; at least 1.6-fold (0.22 log units) between middle value and limit.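

Going by these compounds alone, earlier compounds changed only the ((trifluoromethyl)sulfonyl)carbamoyl group, so this is the first view of the saturated chain carbon bound to an aromatic carbon and a saturated chain carbon. In this assay, 4-chlorobenzyl to 1-(4-chlorophenyl)ethyl gives an at least 2.0-fold higher number from compound 1 to compound 4 (0.30 log units; that floor lies within the scatter), so the full size of the step stays unread and it cannot be placed beyond the scatter. Compound 4 gives > 10 mg/kg, which is a limit and not a number: the limit of > 10 mg/kg in this assay, at which 2 of the 4 values shown sit.

Going by these compounds, it remains open how an ethyl or a hydroxyl on this carbon would read. Also open, on these data alone, is whether the methyl would have the same outcome with 1H-tetrazol-5-yl on the core.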